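Cytotoxicity after a thioxo-for-carbonyl swap on one core

The compounds below may be only part of what the source reports. "The series", "measured", "known", "first", "only" and "open" are said of these compounds alone.

The read-out here is an ADME assay on L6 cells (Rattus norvegicus) for cytotoxicity, read by microscopy and resazurin assay, with a stated time of 72 h; on this read-out higher numbers stand for an effect only at larger amounts of compound and lower numbers for an effect already at smaller amounts. Compound 1 `Cc1cc(/C=C2\S/C(=N\c3ccccc3)N(C3CCCCC3)C2=O)c(C)n1C` reaches only a limit of the assay in this assay, giving > 230000 nM. That limit of compound 1 is the limit of > 230000 nM in this assay, at which 1 of the 2 values shown sits. Among the compounds with values here, compound 2 `Cc1cc(/C=C2/SC(=O)NC2=O)c(C)n1-c1ccccc1C(F)(F)F` gives 43000 nM in this assay, the only plain number among the two values shown. Compound 3 `Cc1cc(/C=C2/SC(=S)NC2=O)c(C)n1-c1ccccc1C(F)(F)F` differs from compound 2 in one place: a group of 8 heavy atoms (4 carbon, 1 nitrogen, 1 oxygen, 2 sulfur; one five-membered non-aromatic ring with 2 hetero atoms) in place of a group of 8 heavy atoms (4 carbon, 1 nitrogen, 2 oxygen, 1 sulfur; one five-membered non-aromatic ring with 2 hetero atoms), on an aromatic carbon. Within the data shown here, no measured pair shows how this swap acts in this assay, so its size is not known from the data. The expectation for compound 3 is a small shift, if any, toward an effect at smaller amounts, a 1.4-fold lower number from compound 2 to compound 3 (0.16 log units; within the scatter), a step that stays within the usual scatter. On that basis compound 3 is estimated at 30000 nM in this assay, with a likely range from 10000 nM to 90000 nM.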

Compound 3, half-maximal effective concentration: 9000 nM
For compound 3 the middle estimate is 3.3-fold (0.52 log units) above the measured one; measured number below the stated range.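

Within the data shown here, this is the first measured pair at this position. Exchanging a single oxygen for sulfur in the five-membered non-aromatic ring group, on the same aromatic carbon and with the rest of the molecule unchanged, gives a 4.8-fold lower number from compound 2 to compound 3 (0.68 log units; beyond the scatter) in this assay. The counts of heavy atoms, hydrogen-bond donors and hydrogen-bond acceptors in the group stay the same, so a change of one atom is enough to move the cytotoxic effect to smaller amounts of compound. Nothing measured here explains why this one atom has that effect.

Going by these compounds, whether a carboxylic acid or an amine at this position would move the number further remains open. Compound 1 gives only a limit of the assay, > 230000 nM, and it differs from the other compounds in more than one place, so it cannot show how the same swap would act on its core.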